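Cyclic amine ring size in the urea series

The source may report more compounds than this note shows. Statements on the series, on what has been measured and on what is new or still open speak of the compounds shown alone.

Compound 1, `CN(C)c1ccc(CNC(=O)Nc2cccc3cnccc23)cc1`: 157 nM in a functional assay for antagonist activity at transient receptor potential cation channel subfamily V member 1 (Homo sapiens), read by calcium flux; on this read-out lower numbers stand for stronger inhibition and higher numbers for weaker inhibition
Compound 2, `O=C(NCc1ccc(N2CCCC2)cc1)Nc1cccc2cnccc12`: 5.3 nM in this assay
Compound 3, `O=C(NCc1ccc(N2CCCCC2)cc1)Nc1cccc2cnccc12`: 7.3 nM in this assay

Compound 3 holds the second highest of the three numbers. Its nearest neighbour is compound 2, where the move a 1.4-fold higher number from compound 2 to compound 3 (0.14 log units; within the scatter) stays within the scatter. The furthest is compound 1, from which the step of a 22-fold lower number from compound 1 to compound 3 (1.33 log units; beyond the scatter) is large, as is the parallel step a 30-fold lower number from compound 1 to compound 2 (1.47 log units; beyond the scatter).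

Compound 4, `O=C(NCc1ccc(N2CCCCCC2)cc1)Nc1cccc2cnccc12`, is not yet measured. It differs from compound 3 by azepan-1-yl in place of piperidin-1-yl on an aromatic carbon.

For the measured compounds named here, only the step from compound 2 to compound 3 bears directly on a ring enlargement at this position, and it was within the scatter. The two large steps from compound 1 concern the exchange of an acyclic amine for a cyclic one and say nothing about ring size beyond that. The expectation for this assay is therefore a step of a 1.4-fold higher number from compound 3 to compound 4 (0.14 log units; within the scatter) of small size, most likely none beyond the scatter, with a slight lean toward a higher number. The estimate for compound 4 is 10 nM, expected to lie between 4 nM and 25 nM.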

Compound 4, half-maximal inhibitory concentration: 3.3 nM
Compound 4: middle estimate off by 3.0-fold (0.48 log units), on the high side; the whole stated range lies above it.
By their numbers in this assay, from the lowest: compounds 4, 2 and 3 (each within the scatter of the next, the first and the last beyond it); then compound 1.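

In this assay, for the compounds shown here, the change from piperidin-1-yl to azepan-1-yl gives a 2.2-fold lower number from compound 3 to compound 4 (0.34 log units; beyond the scatter) and is the first ring enlargement at this position to pass beyond the scatter, toward stronger inhibition, so the seven-membered ring is accepted here. The comparison with the smaller ring, a 1.6-fold lower number from compound 2 to compound 4 (0.21 log units; within the scatter) within the scatter, and the comparison with the acyclic amine, a 48-fold lower number from compound 1 to compound 4 (1.68 log units; beyond the scatter) and thus large, show that the advantage over dimethylamino seen with pyrrolidin-1-yl and piperidin-1-yl extends to azepan-1-yl. No available evidence bears on why the piperidin-1-yl to azepan-1-yl step runs in this direction.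

Open, going by these compounds, is whether a still larger azocan-1-yl ring continues this trend, and whether a ring holding a second hetero atom, such as morpholin-4-yl or piperazin-1-yl, is accepted at this position. An acyclic diethylamino group would show whether the advantage over dimethylamino requires a ring at all.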